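Same atoms, joined differently: estimating compound 4

The compounds below may be only part of what the source reports. "The series", "measured", "known", "first", "only" and "open" are said of these compounds alone.

In a physicochemical assay for solubility, at pH 6.8 (a higher number here means a more soluble compound, a lower number a less soluble compound), compound 1 `Cn1cc(-c2ccc(N(C(=O)NCc3ccccc3)C3CCC(Nc4ccc(C#N)cn4)CC3)cc2)cn1` gives 0.33 ug/mL. Within the data shown here, compound 2 `Cn1cccc(-c2ccc(N(C(=O)NCc3ccccc3)C3CCC(Nc4ccc(C#N)cn4)CC3)cc2)c1=O` gives 4.7 ug/mL, the highest number so far. Compound 3 `Cn1c(-c2ccc(N(C(=O)NCc3ccccc3)C3CCC(Nc4ccc(C#N)cn4)CC3)cc2)cccc1=O` gives < 0.09 ug/mL, which is a limit of the assay and not a number. Compound 4 `Cn1ccc(-c2ccc(N(C(=O)NCc3ccccc3)C3CCC(Nc4ccc(C#N)cn4)CC3)cc2)cc1=O` has the same atoms as compound 2, joined differently: a group of 8 heavy atoms (6 carbon, 1 nitrogen, 1 oxygen; one six-membered aromatic ring with 1 hetero atom) in place of a group of 8 heavy atoms (6 carbon, 1 nitrogen, 1 oxygen; one six-membered aromatic ring with 1 hetero atom), on an aromatic carbon. Among the measured compounds shown here, the closest guide is the one other swap of this kind, which gave an at least 52-fold lower number from compound 2 to compound 3 (1.71 log units; beyond the scatter). Replacing the five-membered ring gave both a 14-fold higher number from compound 1 to compound 2 (1.15 log units; beyond the scatter) and an at least 3.6-fold lower number from compound 1 to compound 3 (0.56 log units; beyond the scatter), so such swaps can go either way. From the top of the set, a lower number is expected in this assay, an estimated 4.7-fold lower number from compound 2 to compound 4 (0.67 log units; beyond the scatter). Compound 4 is estimated at 1 ug/mL, with an expected range of 0.15 ug/mL to 6 ug/mL.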

Compound 4, solubility: < 0.08 ug/mL
Compound 4 ended at the assay's limit (the forecaster's own chance of this, stated with the estimate: 12%); middle value at least 12-fold (1.09 log units) away from the limit.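

Compound 4 gives < 0.08 ug/mL, which is a limit of this assay and not a number. Joining the same atoms differently gives an at least 58-fold lower number from compound 2 to compound 4 (1.76 log units; beyond the scatter), and swapping in this ring for the five-membered ring gives an at least 4.1-fold lower number from compound 1 to compound 4 (0.61 log units; beyond the scatter). Of the three compounds carrying a six-membered ring with these atoms, only compound 2 now stands above compound 1, and the step from compound 3 to compound 4 cannot be read, since both are limits.

Going by these compounds, what sets compound 2 apart stays open. So does whether an amine on the ring of compound 4 would bring it to a readable number.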